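The compounds below may be only part of what the source reports. "The series", "measured", "known", "first", "only" and "open" are said of these compounds alone.

Measured in a functional assay on NZB5 cells (Homo sapiens) for inhibition, read by thymidine incorporation, with a stated time of 5 days; on this read-out higher numbers stand for weaker inhibition and lower numbers for stronger inhibition:
- compound 1 `Cc1ccc(C)c(S(=O)(=O)N(C)/N=C/c2cnn3ccc(C#N)cc23)c1`: 2100 nM
- compound 2 `CN(/N=C/c1cnn2ccc(C#N)cc12)S(=O)(=O)c1cc([N+](=O)[O-])ccc1F`: 480 nM
- compound 3 `CN(C)c1ccc([N+](=O)[O-])cc1S(=O)(=O)N(C)/N=C/c1cnn2ccc(C#N)cc12`: 40 nM

Compound 3 has the lowest number of the three, and its gaps to both others lie beyond the scatter. Compound 4 `CC(C)c1ccc([N+](=O)[O-])cc1S(=O)(=O)N(C)/N=C/c1cnn2ccc(C#N)cc12` carries isopropyl in place of dimethylamino on an aromatic carbon, para to a nitro group: isopropyl in place of dimethylamino on an aromatic carbon. Among the measured compounds shown here, the only measured step at this carbon is large: a 12-fold lower number from compound 2 to compound 3 (1.08 log units; beyond the scatter). For the measured compounds named here, compound 1 differs from the others in more than one place and gives no clean step. Going by the values given here, no measured compound carries isopropyl, so a moderate move to a higher number in this assay, smaller than that step, is expected. The estimated change is a 2.5-fold higher number from compound 3 to compound 4 (0.40 log units; beyond the scatter). For compound 4 the expected value is 100 nM, with an estimated range of 30 nM to 350 nM.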

Compound 4, half-maximal inhibitory concentration: 180 nM
Estimate against measurement, compound 4: 1.8-fold (0.26 log units) below; the range from low to high includes it.
By their numbers in this assay, from the lowest: compound 3; then compound 4; then compound 2; then compound 1.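

At this carbon, para to a nitro group, the low number is not confined to dimethylamino: in this assay, replacing fluoro with isopropyl, which has no hydrogen-bond acceptor, still gives a 2.7-fold lower number from compound 2 to compound 4 (0.43 log units; beyond the scatter). Dimethylamino nevertheless remains ahead, with a 4.5-fold higher number from compound 3 to compound 4 (0.65 log units; beyond the scatter), so the two groups are not interchangeable here. No measurement available here explains the difference between them. The compounds shown leave open how a methoxy group, a primary amine or morpholine would rank at this carbon. They also leave open whether this order holds if an amine replaces the nitro group.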